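The compounds below may be only part of what the source reports. "The series", "measured", "known", "first", "only" and "open" are said of these compounds alone.

Working notes on the series. Compound 1 `COc1cc(-c2nnc(SCc3ccc([N+](=O)[O-])cc3)o2)ccc1O` gives 14200 nM in a functional assay on cells (T-cell, Mus musculus, strain BALB/c) for inhibition, read by MTT assay, with stated times of 24 h and 72 h; a higher number here means a weaker inhibitor, a lower number a stronger inhibitor; compound 2 `COc1cc(-c2nnc(SCc3ccc(C)cc3)o2)ccc1O` gives 6210 nM, and compound 3 `COc1cc(-c2nnc(SCc3c(F)cccc3F)o2)ccc1O` gives 10100 nM, the second highest of the three numbers and within the scatter of both others. Compound 4 `COc1cc(-c2nnc(SCc3ccc(F)cc3)o2)ccc1O` is not yet measured. Its change from compound 3: 4-fluorophenyl in place of 2,6-difluorophenyl on a saturated chain carbon bound to a sulfur. Going by the values given here, the steps that bear on it are a 2.3-fold lower number from compound 1 to compound 2 (0.36 log units; beyond the scatter) and a 1.6-fold higher number from compound 2 to compound 3 (0.21 log units; within the scatter), the second being the only one at this position and within the scatter. Compound 4 is therefore expected to sit close to compound 3, a step of a 1.3-fold lower number from compound 3 to compound 4 (0.13 log units; within the scatter) at most, if anything toward a lower number. The estimate for compound 4 is 7500 nM, within 3500 nM to 16000 nM.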

Compound 4, half-maximal inhibitory concentration: 8190 nM
The estimate for compound 4 lay 1.1-fold (0.04 log units) below the measured number, and the stated range covers the measured number.
By their numbers in this assay, from the lowest: compounds 2, 4, 3 and 1 (each within the scatter of the next, the first and the last beyond it).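

Compound 4 adds three steps in this assay that stay inside the scatter: the change of aryl group on the saturated chain carbon bound to a sulfur (a 1.2-fold lower number from compound 3 to compound 4 (0.09 log units; within the scatter)), the fluoro against methyl (a 1.3-fold higher number from compound 2 to compound 4 (0.12 log units; within the scatter)) and the fluoro against nitro (a 1.7-fold lower number from compound 1 to compound 4 (0.24 log units; within the scatter)). Fluoro therefore separates from neither methyl nor nitro, although those two lie beyond the scatter of each other, and 4-fluorophenyl does not separate from 2,6-difluorophenyl. Nothing available explains these results. As far as these compounds go, whether an amine or a carboxylic acid in place of the fluoro, or a longer chain at the saturated chain carbon bound to a sulfur, would move the number beyond the scatter remains open.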